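Replacing the chlorophenyl group with a methoxyphenyl group

The source may report more compounds than this note shows. Statements on the series, on what has been measured and on what is new or still open speak of the compounds shown alone.

Compound 3 `COc1cc(OC)c(OC)cc1/C=C/COC(=O)/C=C/c1ccccc1Cl` gives 50% in a functional assay on the whole organism (strain Kunming) with Mus musculus as the target, with a stated time of 0.5 h, at a dose of 300 mg/kg by the intraperitoneal route (a lower number here means a stronger effect, a higher number a weaker effect of the compound at the dose given), the lowest of the three numbers measured. Compound 1 `COc1cc(OC)c(OC)cc1/C=C/COC(=O)/C=C/c1ccc(OC)c(OC)c1` gives 75% and compound 2 `COc1cc(OC)c(OC)cc1/C=C/COC(=O)/C=C/c1ccc(Br)cc1` gives 75%; the step of no change at the digits printed from compound 1 to compound 2 (within the scatter) lies within the scatter, whereas a number 25 percentage points lower from compound 1 to compound 3 (beyond the scatter) and a number 25 percentage points lower from compound 2 to compound 3 (beyond the scatter) both lie beyond it. Compound 4 `COc1cccc(/C=C/C(=O)OC/C=C/c2cc(OC)c(OC)cc2OC)c1` differs from compound 3 in one place: 3-methoxyphenyl in place of 2-chlorophenyl on a double-bonded chain carbon bound to a double-bonded chain carbon. The two steps that bear on this change are those that brought the 2-chlorophenyl group in, each lowering the number by a modest amount; removing it again is expected to recover roughly that amount, so the step of a number 20 percentage points higher from compound 3 to compound 4 (beyond the scatter) is expected to be an increase beyond the scatter. Compound 4 is therefore estimated at 70%, within the range 50% to 90%.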

Compound 4, a percentage reported as activity, at one dose (the size of the read-out at that dose, not a potency): 75%
Beside the measured number, compound 4's estimate is 5 percentage points below it; low and high end bracket the measured number.
By their numbers in this assay, from the lowest: compound 3; then compounds 1, 2 and 4 (each within the scatter of the next).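

In this assay, 3-methoxyphenyl in place of 2-chlorophenyl gives a number 25 percentage points higher from compound 3 to compound 4 (beyond the scatter) and so takes the number back up to where the other compounds stand. 3-Methoxyphenyl in place of 4-bromophenyl gives no change at the digits printed from compound 2 to compound 4 (within the scatter) and hydrogen in place of methoxy on an aromatic carbon gives no change at the digits printed from compound 1 to compound 4 (within the scatter), so the 3,4-dimethoxyphenyl, 4-bromophenyl and 3-methoxyphenyl groups read alike at this place, and only compound 3 goes against them. Nothing available accounts for this result. Going by these compounds, whether 3-chlorophenyl or 4-chlorophenyl would read like 2-chlorophenyl stays open. So does the reading for a phenyl group carrying an amine or a carboxylic acid here.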